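The source may hold more compounds than are shown below. What is called first, only, known or untested is meant among the compounds shown, and "the series" means these compounds.

Three analogues of one core have so far been taken through an ADME assay on cells (Macrophage, Homo sapiens) for cytotoxicity, read by MTT assay, with a stated time of 24 h; a lower number here means that less compound is tolerated, a higher number that more compound is tolerated. Compound 1 `CC(O)Cn1c([N+](=O)[O-])cnc1/C=C/c1cccc(F)c1` gives 1030 nM there; compound 2 `COc1cccc(/C=C/c2ncc([N+](=O)[O-])n2CC(C)O)c1` gives 1300 nM; compound 3 `CC(O)Cn1c([N+](=O)[O-])cnc1/C=C/c1cccc(Br)c1` gives 620 nM. Among the compounds with values here, compound 3 thus holds the lowest of the three numbers, though against compound 1 the gap is within the scatter, and only the step of a 2.1-fold lower number from compound 2 to compound 3 (0.32 log units; beyond the scatter) goes beyond it. Compound 4 `CC(O)Cn1c([N+](=O)[O-])cnc1/C=C/c1cccc([N+](=O)[O-])c1` differs from compound 3 by nitro in place of bromo on an aromatic carbon. Within the data shown here, the steps that bear on this all swap one group at that same aromatic carbon: a 1.3-fold higher number from compound 1 to compound 2 (0.10 log units; within the scatter) and a 1.7-fold lower number from compound 1 to compound 3 (0.22 log units; within the scatter), both within the scatter, plus the modest one above. Among the measured compounds shown here, no nitro analogue has been measured. A small step is therefore expected, a 1.3-fold higher number from compound 3 to compound 4 (0.11 log units; within the scatter), direction open. Compound 4 is estimated at 800 nM, range 400 nM to 1600 nM.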

Compound 4, half-maximal cytotoxic concentration: 430 nM
Compound 4: the middle estimate sits 1.9-fold (0.27 log units) above what was measured; the measured number falls inside the stated range.
By their numbers in this assay, from the lowest: compounds 4, 3, 1 and 2 (each within the scatter of the next, the first and the last beyond it).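

At this aromatic carbon, nitro in place of bromo remains a small change in this assay: a 1.4-fold lower number from compound 3 to compound 4 (0.16 log units; within the scatter). Nitro nevertheless stands clear of both remaining groups, a 3.0-fold lower number from compound 2 to compound 4 (0.48 log units; beyond the scatter) and a 2.4-fold lower number from compound 1 to compound 4 (0.38 log units; beyond the scatter), whereas bromo stood clear of methoxy alone, so the two ends of the series now separate more distinctly. No available measurement explains these differences. From the compounds shown here alone, whether an amine or a carboxylic acid at this carbon would extend the spread or stay within it remains open. So does the effect of a longer chain there.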